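Chromane piperazines: removing the pyridin-2-yl group

The source may report more compounds than this note shows. Statements on the series, on what has been measured and on what is new or still open speak of the compounds shown alone.

compound 1 `CC(=O)Oc1c(C)c(C)c2c(c1C)CCC(C)(CN1CCN(c3cc(N4CCCC4)nc(N4CCCC4)n3)CC1)O2` — 1500 nM
compound 2 `Cc1c(C)c2c(c(C)c1O)CCC(C)(CN1CCN(c3ccccn3)CC1)O2` — 1000 nM

In a functional assay (brain) for inhibition, with Rattus norvegicus as the target (on this read-out higher numbers stand for weaker inhibition and lower numbers for stronger inhibition), compound 1 gives 1500 nM and compound 2 gives 1000 nM. Compound 2 carries the smaller of the two numbers, but the gap to compound 1 is within the scatter, so the two cannot be separated on this read-out.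

Compound 3 `Cc1c(C)c2c(c(C)c1O)CCC(C)(CN1CCNCC1)O2` differs from compound 2 in one place: hydrogen in place of pyridin-2-yl on an amine nitrogen in a ring. Within the data shown here, no measured pair here isolates this change, so nothing in the data fixes its size or direction. A moderate weakening of inhibition is expected, a 3.0-fold higher number from compound 2 to compound 3 (0.48 log units; beyond the scatter). Compound 3 is estimated at 3000 nM, with a range from 800 nM to 12000 nM.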

Compound 3, half-maximal inhibitory concentration: 1000 nM
The estimate for compound 3 lay 3.0-fold (0.48 log units) above the measured number, within the range that was stated.
By their numbers in this assay, from the lowest: compounds 2, 3 and 1 (each within the scatter of the next).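

In this assay there is no change at the digits printed from compound 2 to compound 3 (within the scatter) when hydrogen takes the place of pyridin-2-yl on an amine nitrogen in a ring, so in this pair that aromatic ring is not needed to keep the inhibition read here. Nothing measured in the series accounts for this result.

The compounds shown leave open whether a methyl, benzyl or acetyl group on this nitrogen would shift the number. They also leave open whether the same replacement reads alike on the core of compound 1, which carries an acetate ester.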